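Toxicity on Vero cells: from a fluorophenyl to a pyridyl

The source may hold more compounds than are shown below. What is called first, only, known or untested is meant among the compounds shown, and "the series" means these compounds.

Measured so far in a toxicity assay on Vero cells (Chlorocebus sabaeus) for cytotoxicity; a lower number here means that less compound is tolerated, a higher number that more compound is tolerated:
- compound 1, `COc1nc(-c2ccccc2F)ccc1[C@@H](c1ccccc1)[C@@](O)(CCN(C)C)c1cccc2ccccc12`: > 50 ug/mL
- compound 2, `COc1ncc(-c2ccccc2)cc1[C@@H](c1ccccc1)[C@@](O)(CCN(C)C)c1cc(F)ccc1F`: > 50 ug/mL
- compound 3, `COc1ncc(-c2ccccc2)cc1[C@@H](c1ccccc1)[C@@](O)(CCN(C)C)c1cc(F)cc(F)c1`: > 50 ug/mL

Each of these three values is a limit of the assay, not a number. Compound 1 therefore stands at the limit of > 50 ug/mL in this assay, at which 3 of the 3 values shown sit, and the other two measured compounds sit at the same limit. For the measured compounds named here, the only step between measured compounds that differ in one place is a step that the two limits leave unreadable from compound 2 to compound 3, and its size cannot be read, since both ends are limits.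

The compound still to be measured is compound 4, `COc1nc(-c2ccncc2)ccc1[C@@H](c1ccccc1)[C@@](O)(CCN(C)C)c1cccc2ccccc12`. Compared with compound 1 the change is pyridin-4-yl in place of 2-fluorophenyl on an aromatic carbon. No measured step touches this position, and the one step shown, from compound 2 to compound 3, gives no readable size; so nothing here points to a change beyond the scatter in this assay. The expectation is that compound 4 behaves like compound 1, with a step that the limit leaves unreadable from compound 1 to compound 4 as the estimated step, most likely ending again at a limit. For compound 4 the estimated value in this assay is 60 ug/mL, with a range from 30 ug/mL to 120 ug/mL.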

Compound 4, half-maximal cytotoxic concentration: > 50 ug/mL
Compound 4 ended at the assay's limit; the forecaster's own chance of this, stated with the estimate: 80%; the middle value is on the limit's open side.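

In this assay, compound 1 and compound 4 both end at a limit rather than at a number, so no size can be read for the exchange of 2-fluorophenyl for pyridin-4-yl: the limit of > 50 ug/mL in this assay, at which 4 of the 4 values shown sit.

The compounds shown leave open whether compound 1 and compound 4 differ at all in this assay: none of the four compounds has an exact number there.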